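Swapping a Bicyclic Amide for Diisobutylamino in Compound 2

The compounds below may be only part of what the source reports. "The series", "measured", "known", "first", "only" and "open" are said of these compounds alone.

Of the compounds shown here, two have been measured so far. Compound 1 `Cc1cccc(Oc2ccnc(N3CCC[C@H]3C(=O)NCc3cccnc3)n2)c1` and compound 2 `Cc1cccc(N(C)c2cc(Nc3cccc(C(=O)N4CCCC5CCCCC54)c3)ncn2)c1` were both tested in an assay on isolated protein for inhibition of tyrosine-protein kinase ZAP-70 (Homo sapiens), read by HTRF, tested at 10 uM; on this read-out higher numbers stand for more inhibition at the one concentration tested (going by the name of the read-out) and lower numbers for less inhibition. In this assay compound 1 gives 6%, and compound 2 gives 0%. On these numbers compound 2 stands at the bottom, yet its gap to compound 1 is within the usual scatter of this kind of measurement, so the two cannot be told apart; both show almost no inhibition at the concentration tested.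

Compound 3 `Cc1cccc(N(C)c2cc(Nc3cccc(C(=O)N(CC(C)C)CC(C)C)c3)ncn2)c1` has not yet been measured. It differs from compound 2 at a single place: a group of 9 heavy atoms (8 carbon, 1 nitrogen; no ring) in place of a group of 10 heavy atoms (9 carbon, 1 nitrogen; one six-membered non-aromatic ring of carbon only, one six-membered non-aromatic ring with 1 hetero atom), on a carbonyl carbon. The rest of the shared core is kept.

Going by the values given here, no step between measured compounds that differ in one place is available, so the expectation rests only on the two values above. Because compound 1 gives 6% and compound 2 gives 0%, nothing here suggests that the new group would lift inhibition. The estimated step is a number 2 percentage points higher from compound 2 to compound 3 (within the scatter), which is no change beyond the scatter. Compound 3 is expected to give 2% in this assay, with a range from -8% to 12%.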

Compound 3, a percentage reported as inhibition, at one concentration (the size of the read-out at that concentration, not a potency): 0%
Estimate against measurement, compound 3: 2 percentage points above, within the range that was stated.
By their numbers in this assay, from the lowest: compounds 2, 3 and 1 (each within the scatter of the next).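

In this assay, going by these compounds alone, putting diisobutylamino, a group with no ring, in place of the two-ring group on the carbonyl carbon gives no change at the digits printed from compound 2 to compound 3 (within the scatter) and is the first one-place change that can be read. Within the data shown here, compound 2 already gives 0%, which leaves no room on this read-out for a loss to show, so the step says only that this exchange brings no gain in inhibition and does not show that the group at this position is unimportant. Nothing available explains the unchanged value.

The compounds shown leave open whether a group containing a further hetero atom on this carbonyl carbon, such as morpholine or a chain ending in a carboxylic acid, would lift inhibition clear of the scatter. They also leave open whether a change elsewhere on the shared core, such as an amine in place of the methyl group on the aromatic ring, would raise the read-out enough for changes at this position to become visible.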